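A few compounds are considered here, and "the series" means these few. Any claim that something is new, unique, unknown or untested is made for them only; others in the source may bear on it.

Compound 1 `O=C1C[C@@H]2O[C@@H]([C@H](O)c3ccccc3)[C@@H](O)[C@@H]2O1` and compound 2 `O=C1C[C@H]2O[C@H]([C@@H](O)c3ccccc3)[C@H](O)[C@H]2O1` share every atom and bond and are drawn as mirror images of each other. In an ADME assay on MRC5 cells (Homo sapiens) for cytotoxicity, read by MTT assay, with a stated time of 72 h (on this read-out higher numbers stand for weaker inhibition and lower numbers for stronger inhibition), compound 1 gives > 100000 nM, which is a limit of the assay and not a number. In the same assay compound 2 gives > 100000 nM, again only a limit. Going by the values given here, the step that the two limits leave unreadable from compound 1 to compound 2 therefore has no readable size because the limit of > 100000 nM in this assay, at which 3 of the 3 values shown sit, hides whatever lies beyond it, even though the fact that compounds 1 and 2 differ only in the configuration as drawn makes this the one measured pair that mirrors the change considered here.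

Compound 3 `O=C(/C=C/c1ccccc1)O[C@H](c1ccccc1)[C@H]1O[C@@H]2CC(=O)O[C@@H]2[C@H]1O` stands at > 100000 nM in this assay, once more a limit and not a number. Compound 4 `O=C(/C=C/c1ccccc1)O[C@@H](c1ccccc1)[C@@H]1O[C@H]2CC(=O)O[C@H]2[C@@H]1O` differs from compound 3 by the two compounds have the same atoms and bonds and differ only in configuration as drawn: 5 of 6 stereo elements differ; a stereocentre at a saturated chain carbon is drawn R in compound 3 and S in compound 4; a stereocentre at a saturated ring carbon is drawn S in compound 3 and R in compound 4; a stereocentre at a saturated ring carbon is drawn R in compound 3 and S in compound 4; a stereocentre at a saturated ring carbon is drawn R in compound 3 and S in compound 4. Among the compounds with values here, the only measured step that bears on this change is the one from compound 1 to compound 2, and its size cannot be read. No step beyond the scatter is expected in this assay, so compound 4 is estimated at 150000 nM, within 60000 nM to 500000 nM, which corresponds to an expected step that the limit leaves unreadable from compound 3 to compound 4.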

Compound 4, half-maximal inhibitory concentration: > 100000 nM
Compound 4: only a limit was reported; the forecaster's own chance of this, stated with the estimate: 85%; the middle value lies beyond the limit too.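

Going by these compounds alone, compound 3 and compound 4 both stand at a limit, not a number, in this assay, and no step between them can be read. The compounds shown leave open whether configuration as drawn matters at all in this assay, with none of them giving a readable number there.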